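The compounds below may be only part of what the source reports. "The series", "measured", "known", "first", "only" and "open" are said of these compounds alone.

Of the compounds shown here, two built on a shared core have been measured so far, compound 1 (`C=C1CC[C@@H]2[C@](C)(COC(=O)c3cccnc3)[C@H](O)CC[C@@]2(C)[C@@H]1/C=C/C1=CCOC1=O`) and compound 2 (`C=C1CC[C@@H]2[C@](C)(COC(=O)/C=C/c3ccccc3)[C@H](O)CC[C@@]2(C)[C@@H]1C/C=C1\C=COC1=O`). In an ADME assay on HepG2 2.2.15 cells (Homo sapiens) for cytotoxicity, read by MTT assay (on this read-out lower numbers stand for higher toxicity in this test and higher numbers for lower toxicity in this test), compound 1 gives 113000 nM and compound 2 gives 271000 nM as the higher of the two numbers, a gap beyond the usual scatter. Compound 3 (`C=C1CC[C@@H]2[C@](C)(COC(=O)c3cccnc3)[C@H](O)CC[C@@]2(C)[C@@H]1C/C=C1\C=COC1=O`) matches compound 2 except on a carbonyl carbon (pyridin-3-yl in place of 2-phenylethenyl on a carbonyl carbon). Among the compounds with values here, no measured step isolates this change. Compound 1 also carries pyridin-3-yl on a carbonyl carbon, differs elsewhere, and stands at 113000 nM on the lower side, so a modest step to a lower number in this assay is expected, one that may stay within the scatter. The estimated change is a 1.6-fold lower number from compound 2 to compound 3 (0.20 log units; within the scatter) in this account. The expected value for compound 3 is 170000 nM within an estimated range from 80000 nM to 350000 nM overall.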

Compound 3, half-maximal cytotoxic concentration: 2050000 nM
Compound 3: middle estimate off by 12-fold (1.08 log units), on the low side; measured number above the stated range.
By their numbers in this assay, from the lowest: compound 1; then compound 2; then compound 3.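

With the rest of compound 2 held fixed, exchanging 2-phenylethenyl for pyridin-3-yl on a carbonyl carbon gives a 7.6-fold higher number from compound 2 to compound 3 (0.88 log units; beyond the scatter) in this assay, so this position clearly affects the read-out, and here the change goes towards lower toxicity in this test. Pyridin-3-yl does not set the number alone: with it in both compounds, exchanging the group on a saturated ring carbon gives an 18-fold higher number from compound 1 to compound 3 (1.26 log units; beyond the scatter), a large step. Nothing available explains either step.

Open, as far as these compounds go, is whether the step at the carbonyl carbon follows from the ring nitrogen of pyridin-3-yl or from the double bond that leaves with 2-phenylethenyl; a plain phenyl group there would separate the two. Also open, from the compounds shown here alone, is whether the same exchange gives a step of similar size alongside the group that compound 1 carries on the saturated ring carbon.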